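Swapping an isopentyl chain for cyclopropylmethyl

The source may hold more compounds than are shown below. What is called first, only, known or untested is meant among the compounds shown, and "the series" means these compounds.

Compound 2 `CC(C)CCN1C(=O)C(C2=NS(=O)(=O)c3cc(NS(C)(=O)=O)ccc3N2)=C(O)[C@H]2CCC[C@H]21` gives 0.383 h in an in vitro ADME assay on microsomes from liver (Homo sapiens) for metabolic stability; on this read-out higher numbers stand for a longer-lived compound and lower numbers for a shorter-lived compound. Compound 1 `CC(C)CCN1C(=O)C(C2=NS(=O)(=O)c3cc(NS(C)(=O)=O)ccc3N2)=C(O)C2CCCC21`, whose two ring stereocentres are drawn without configuration, gives 0.167 h in this assay, and the step of a 2.3-fold higher number from compound 1 to compound 2 (0.36 log units; beyond the scatter) is modest. Compound 3 `CS(=O)(=O)Nc1ccc2c(c1)S(=O)(=O)N=C(C1=C(O)C3CCCCC3N(Cc3ccc(F)cc3)C1=O)N2` differs in two places from compound 2; in this assay compound 3 gives > 1 h, which is a limit of the assay rather than a number. Among the two numbers shown, compound 2 has the higher one. Compound 4 `CS(=O)(=O)Nc1ccc2c(c1)S(=O)(=O)N=C(C1=C(O)[C@H]3CCC[C@H]3N(CC3CC3)C1=O)N2` carries cyclopropyl in place of isobutyl on a saturated chain carbon bound to an amide-type nitrogen in a ring. Among the measured compounds shown here, none of the measured steps covers this change, so no direct guide exists. Compound 4 is expected to give about 0.5 h in this assay, between 0.25 h and 1.1 h. This estimate means a step of a 1.3-fold higher number from compound 2 to compound 4 (0.12 log units; within the scatter), expected to stay within the scatter.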

Compound 4, half-life: > 1 h
Compound 4: a limit, no number; the forecaster's own chance of this, stated with the estimate: 15%; middle value at least 2.0-fold (0.30 log units) from the limit.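

In this assay compound 4 gives > 1 h, which is a limit of the assay and not a number. Cyclopropyl in place of isobutyl on a saturated chain carbon bound to an amide-type nitrogen in a ring brings an at least 2.6-fold higher number from compound 2 to compound 4 (0.41 log units; beyond the scatter), so this position responds to the group it carries, which no earlier step showed. The full size of this step stays unknown because the read-out ends at a limit: the limit of > 1 h in this assay, at which 2 of the 4 values shown sit.

Going by these compounds, whether a longer chain, an amine or a carboxylic acid at this place would give a similar half-life remains open.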